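This account rests on a few compounds, and the source may have more. Where it says the series, first, only, none or still open, it means among the compounds named here.

Values in a functional assay on MDA-MB-361 cells (Homo sapiens) for antiproliferative activity, read by MTT assay, with a stated time of 72 h (on this read-out lower numbers stand for stronger inhibition and higher numbers for weaker inhibition), follow.
- compound 1 `Cc1cc(N/C=C2\C(=O)NN=C2c2ccccc2)n[nH]1` gives 96100 nM
- compound 2 `Cc1cc(N/C=C2\C(=O)N(c3ccccc3)N=C2c2ccccc2)n[nH]1` gives 9980 nM
- compound 3 `O=C1/C(=C\Nc2cc(-c3ccccc3)[nH]n2)C(c2ccccc2)=NN1c1ccccc1` gives 12200 nM

Compound 2 stands at the low end of these numbers, level with compound 3 and well apart from compound 1.

Compound 4 `O=C(O)[C@H](CO)N/C=C1\C(=O)N(c2ccccc2)N=C1c1ccccc1` keeps the core of compound 2 and carries one change on the amine nitrogen: 1-carboxy-2-hydroxyethyl in place of 5-methyl-1H-pyrazol-3-yl on an amine nitrogen.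

Going by the values given here, two measured steps bear on this only indirectly. The phenyl on the amide-type nitrogen, which compound 4 retains, came with a 9.6-fold lower number from compound 1 to compound 2 (0.98 log units; beyond the scatter). Phenyl in place of methyl on the departing ring gave a 1.2-fold higher number from compound 2 to compound 3 (0.09 log units; within the scatter). Among the compounds with values here, no measured compound lacks that ring, so the size of this step is poorly constrained.

A higher number is expected, with a 3.5-fold higher number from compound 2 to compound 4 (0.54 log units; beyond the scatter) as the expected step. Compound 4 is estimated at 35000 nM, with an expected range of 10000 nM to 120000 nM.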

Compound 4, half-maximal inhibitory concentration: 52800 nM
Compound 4: the middle estimate sits 1.5-fold (0.18 log units) below what was measured; the range from low to high includes it.
By their numbers in this assay, from the lowest: compounds 2 and 3 (each within the scatter of the next); then compounds 4 and 1 (each within the scatter of the next).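

In this assay, 1-carboxy-2-hydroxyethyl in place of 5-methyl-1H-pyrazol-3-yl on the amine nitrogen gives a 5.3-fold higher number from compound 2 to compound 4 (0.72 log units; beyond the scatter). Going by these compounds alone, compounds 1, 2 and 3 all keep a five-membered aromatic ring on that nitrogen, so this step is the first direct reading of replacing that group whole, and it costs activity. No measurement at hand accounts for the step.

Still open, as far as these compounds go, is whether the step follows from losing the ring or from the carboxylic acid or hydroxyl entering. A methyl ester, a primary amide or a plain alkyl chain on the amine nitrogen would help separate these.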